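The source may report more compounds than this note shows. Statements on the series, on what has been measured and on what is new or still open speak of the compounds shown alone.

Compound 4 `Cc1ccccc1NC(=O)CN1CCN(c2nnc(Cc3ccccc3)c3ccccc23)CC1` is the unmeasured member of this set. Its nearest measured relative is compound 2 `COc1ccc(NC(=O)CN2CCN(c3nnc(Cc4ccccc4)c4ccccc34)CC2)cc1OC`, which in a functional assay on A549 cells (Homo sapiens) for cytotoxicity, read by MTT assay, with a stated time of 72 h (on this read-out higher numbers stand for weaker inhibition and lower numbers for stronger inhibition), gives "not active" (no number reported); no number stands for compound 2 in this assay, so it has no place on the numerical scale. The change from compound 2 to compound 4 is 2-methylphenyl in place of 3,4-dimethoxyphenyl on an amide-type nitrogen. Among the compounds with values here, compound 1 `O=C(CN1CCN(c2nnc(Cc3ccncc3)c3ccccc23)CC1)Nc1ccc(F)c(F)c1` gives 3790 nM and compound 3 `O=C(CN1CCN(c2nnc(Cc3ccncc3)c3ccccc23)CC1)Nc1cccc(Br)c1` gives 1530 nM; the step of a 2.5-fold lower number from compound 1 to compound 3 (0.39 log units; beyond the scatter) is the only measured change on the same amide-type nitrogen, it is modest, and it sits on a core that differs from that of compound 2. With no number for compound 2 and only a modest step to draw on, compound 4 is expected to be weak in this assay, estimated at 8000 nM, within 2000 nM to 40000 nM, with a real chance that only an inactive result is returned.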

Compound 4, half-maximal inhibitory concentration: "not active" (no number reported)
No number was reported for compound 4, and the estimate cannot be compared.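

In this assay compound 2 and compound 4 both read "not active", so no step can be read between them. Nothing shown bears on this result. As far as these compounds go, whether any amide-type nitrogen substituent on their shared core gives a numerical value stays open.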